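Furan for thiophene on the shared core

This account rests on a few compounds, and the source may have more. Where it says the series, first, only, none or still open, it means among the compounds named here.

Measured compounds:
compound 1, `O=c1[nH]cnc2c1c(-c1cc3ccccc3o1)cn2[C@@H]1O[C@H](CO)[C@@H](O)[C@H]1O`, > 20000 nM
compound 2, `O=c1[nH]cnc2c1c(-c1ccsc1)cn2[C@@H]1O[C@H](CO)[C@@H](O)[C@H]1O`, 12000 nM
compound 3, `COc1ncnc2c1c(-c1ccsc1)cn2[C@@H]1O[C@H](CO)[C@@H](O)[C@H]1O`, 130 nM

In a functional assay on HL-60 cells (Homo sapiens) for antiproliferative activity, read by XTT assay, with a stated time of 72 h (a lower number here means a stronger inhibitor, a higher number a weaker inhibitor), compound 1 reaches only a limit, > 20000 nM. Compound 2 gives 12000 nM, the higher of the two numbers that are not limits. Compound 3 gives 130 nM, the lower of the two. Among the compounds with values here, the one measured step with a single change, an at least 1.6-fold lower number from compound 1 to compound 2 (0.22 log units; that floor lies within the scatter), is bounded by the limit of compound 1 the limit of > 20000 nM in this assay, at which 1 of the 3 values shown sits, and so cannot be sized beyond its floor.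

Compound 4, `O=c1[nH]cnc2c1c(-c1ccoc1)cn2[C@@H]1O[C@H](CO)[C@@H](O)[C@H]1O`, has not been measured. Its change from compound 2: furan-3-yl in place of thiophen-3-yl on an aromatic carbon. Within the data shown here, the only measured step that touches the same carbon, an at least 1.6-fold lower number from compound 1 to compound 2 (0.22 log units; that floor lies within the scatter), exchanges 1-benzofuran-2-yl for thiophen-3-yl; no measured step exchanges one five-membered ring with one hetero atom for another. With the count of heavy atoms, donors and acceptors kept, the expectation is a step within the scatter, no change at the digits printed from compound 2 to compound 4 (within the scatter). Compound 4 is therefore estimated at 12000 nM, with a range from 5000 nM to 30000 nM.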

Compound 4, half-maximal inhibitory concentration: 6370 nM
For compound 4 the middle estimate is 1.9-fold (0.28 log units) above the measured one; the range from low to high includes it.
By their numbers in this assay, from the lowest: compound 3; then compounds 4 and 2 (each within the scatter of the next). At a limit, above all of these: compound 1.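

In this assay the exchange of one five-membered aromatic ring with 1 hetero atom for another on this aromatic carbon now has a measured step: a 1.9-fold lower number from compound 2 to compound 4 (0.28 log units; within the scatter) and so furan-3-yl and thiophen-3-yl are not told apart in this series. Measured against 1-benzofuran-2-yl, the same carbon now gives an at least 3.1-fold lower number from compound 1 to compound 4 (0.49 log units; beyond the scatter) and this floor clears the scatter, which the earlier step to thiophen-3-yl did not. The value of compound 1 is a limit, and the step from it is a floor only: the limit of > 20000 nM in this assay, at which 1 of the 4 values shown sits.

Open, as far as these compounds go, is how an amine or a carboxylic acid on this carbon would read out in the same cells. Also open, from the compounds shown here alone, is whether furan-3-yl tracks thiophen-3-yl on the methoxy-bearing core of compound 3.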